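This account rests on a few compounds, and the source may have more. Where it says the series, first, only, none or still open, it means among the compounds named here.

Measured in a functional assay on PC-3 cells (Homo sapiens) for cytotoxicity, read by sulforhodamine B assay, with a stated time of 72 h; a higher number here means a weaker inhibitor, a lower number a stronger inhibitor:

- compound 1 `Nc1sc(-c2ccc(Cl)cc2)c(-c2ccc(Cl)cc2)c1C(=O)Nc1ccccc1`: > 50000 nM
- compound 2 `Nc1sc(-c2ccc(Cl)cc2)c(-c2ccc(Cl)cc2)c1C(=O)NC1CC1`: 3680 nM

Among the two values shown, compound 2 holds the only number. The value of compound 1 is a limit of the assay and not a number, as told by the limit of > 50000 nM in this assay, at which 1 of the 2 values shown sits. For the measured compounds named here, the one measured step, an at least 13-fold lower number from compound 1 to compound 2 (1.13 log units; beyond the scatter), came from placing cyclopropyl in place of phenyl on an amide-type nitrogen, and it was large.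

Compound 3 `COC(=O)c1c(N)sc(-c2ccc(Cl)cc2)c1-c1ccc(Cl)cc1` differs from compound 2 by methoxy in place of cyclopropylamino on a carbonyl carbon. Going by the values given here, no measured step exchanges the amide for an ester, so nothing here bears directly on this change. Among the compounds with values here, the measured step does show that what sits on the carbonyl side of the shared core can move this assay strongly, and the cyclopropylamino that gave the only number is now removed. Compound 3 is therefore expected to give a weaker number, an estimated 3.3-fold higher number from compound 2 to compound 3 (0.51 log units; beyond the scatter), with a real chance of a limit. The estimate for compound 3 is 12000 nM, within 2500 nM to 50000 nM.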

Compound 3, half-maximal inhibitory concentration: 2780 nM
For compound 3 the middle estimate is 4.3-fold (0.64 log units) above the measured one, within the range that was stated.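

In this assay, methoxy in place of cyclopropylamino on the carbonyl carbon gives a 1.3-fold lower number from compound 2 to compound 3 (0.12 log units; within the scatter), so the two groups cannot be told apart here, although methoxy brings no ring and no hydrogen-bond donor. Anilino now stands alone among the three groups on this carbonyl carbon, as a second comparison also gives an at least 17-fold lower number from compound 1 to compound 3 (1.25 log units; beyond the scatter), and this holds even though anilino shares its hydrogen-bond donor with cyclopropylamino, so the presence of a donor does not sort the three compounds. Compound 1 carries a limit of the assay and not a number, so the true size of both large steps stays unknown: the limit of > 50000 nM in this assay, at which 1 of the 3 values shown sits.

From the compounds shown here alone, what remains open is whether a carboxylic acid, an ethoxy group or a longer alkoxy chain on this carbonyl carbon would stay level with compound 2 and compound 3 or fall away as compound 1 does. Going by these compounds, it also remains open whether the phenyl ring of anilino alone sets compound 1 apart, a question that benzylamino or cyclohexylamino in the same place could address.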